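Cyclohexyl for methyl on an amine nitrogen: a second instance

This account rests on a few compounds, and the source may have more. Where it says the series, first, only, none or still open, it means among the compounds named here.

Compound 1 `CN/C(=N\CCC(c1ccc(Br)cc1)c1ccccn1)NCCCc1c[nH]cn1` and compound 3 `CN/C(=N\CCCC(c1ccc(Cl)c(Cl)c1)c1ccccn1)NCCCc1c[nH]cn1` are the two methyl-bearing parents in this set. In an assay on cardiac atrium with histamine H2 receptor (Cavia porcellus) as the target (on this read-out higher numbers stand for larger maximal responses and lower numbers for smaller maximal responses), compound 1 gives 0.9. In this assay compound 3 gives 1, which lies within the scatter of compound 1 and beyond it from compound 2. The difference between the two cores is not broken down here. Compound 2 `Brc1ccc(C(CC/N=C(/NCCCc2c[nH]cn2)NC2CCCCC2)c2ccccn2)cc1` is compound 1 with cyclohexyl in place of methyl on an amine nitrogen; in this assay compound 2 gives 0.65, so a number 0.25 lower from compound 1 to compound 2 (beyond the scatter). Compound 4 `Clc1ccc(C(CCC/N=C(/NCCCc2c[nH]cn2)NC2CCCCC2)c2ccccn2)cc1Cl` stands to compound 3 as compound 2 stands to compound 1: cyclohexyl in place of methyl on an amine nitrogen, the same change at a place described in the same words. With one measured instance only, the expectation for compound 4 rests on compound 3 at 1 lowered by a step like a number 0.25 lower from compound 1 to compound 2 (beyond the scatter); a step of a number 0.25 lower from compound 3 to compound 4 (beyond the scatter) is expected. Compound 4 is therefore estimated at 0.75 in this assay, most likely between 0.6 and 0.9. The measured value of compound 4 follows.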

Compound 4, intrinsic activity: the largest response reached, as a fraction of the reference agonist's: 1
Compound 4: middle estimate off by 0.25, on the low side; the whole stated range lies below it.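

In this assay, cyclohexyl in place of methyl on an amine nitrogen gives no change at the digits printed from compound 3 to compound 4 (within the scatter). The change therefore does not carry over at a fixed size from one core to the other, and the step from the first pair is no safe guide to the second: the same change on two cores in this assay, a number 0.25 lower (beyond the scatter) from compound 1 to compound 2 and no change at the digits printed (within the scatter) from compound 3 to compound 4, 0.25 apart, beyond the scatter of two such steps This shows only that, on these two pairs, the outcome of the same change differs with the core; it does not show which difference between the cores goes with the gap, as those cores differ in more than one place, and two pairs set no rule for the series.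

The compounds shown leave open whether the gap follows the length of the chain or the halogens on the aromatic ring, which a core differing from compound 1 in only one of these would separate. Also open, from the compounds shown here alone, is how ethyl, cyclopentyl or benzyl on the same amine nitrogen would compare with methyl and cyclohexyl on each core.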